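Hydrazone aryl swap on a triazole thioether series

The source may report more compounds than this note shows. Statements on the series, on what has been measured and on what is new or still open speak of the compounds shown alone.

Measured compounds:
compound 1, `Brc1ccc(CSc2nnc(-c3ccncc3)n2-c2ccccc2)cc1`, 12900 nM
compound 2, `COc1ccc(/C=N/NC(=O)CSc2nnc(-c3ccncc3)n2-c2ccccc2)cc1`, 27100 nM

In a functional assay on HepG2 cells (Homo sapiens) for inhibition, read by MTT assay, with a stated time of 48 h (a higher number here means a weaker inhibitor, a lower number a stronger inhibitor), compound 2 gives the highest number of the two, with compound 1 giving the lower one; the gap between these two values lies beyond the usual scatter. Compound 3, `O=C(CSc1nnc(-c2ccncc2)n1-c1ccccc1)N/N=C/c1cccc(F)c1`, carries 3-fluorophenyl in place of 4-methoxyphenyl on a carbon with a double bond to nitrogen. Going by the values given here, no measured pair shows this change, so nothing known here points to a direction. The step expected for a 1.1-fold lower number from compound 2 to compound 3 (0.04 log units; within the scatter) is none beyond the scatter. Compound 3 is therefore estimated at 25000 nM in this assay, with a range from 9000 nM to 70000 nM.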

Compound 3, half-maximal inhibitory concentration: 24400 nM
Compound 3: the middle estimate sits 1.0-fold (0.01 log units) above what was measured; low and high end bracket the measured number.
By their numbers in this assay, from the lowest: compounds 1, 3 and 2 (each within the scatter of the next, the first and the last beyond it).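

In this assay the swap of 4-methoxyphenyl for 3-fluorophenyl on the carbon with a double bond to nitrogen gives a 1.1-fold lower number from compound 2 to compound 3 (0.05 log units; within the scatter) and so leaves no readable effect at this position. The group that enters has no hydrogen-bond acceptor and the one that leaves has one, yet the two values stay within the scatter of each other. Nothing at hand accounts for this result.

On these data alone, whether an amine or a carboxylic acid at this place would give a number beyond the scatter of compound 2 stays open. So does the effect of a longer chain there.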